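A few compounds are considered here, and "the series" means these few. Any claim that something is new, unique, unknown or untested is made for them only; others in the source may bear on it.

Of the compounds shown here, three have so far been measured in a physicochemical assay for lipophilicity, read by HPLC, measured as chromatographic lipophilicity, at pH 7.4; on this read-out lower numbers stand for lower lipophilicity and higher numbers for higher lipophilicity. Compound 1 `O=C(c1ccccn1)N1N=CCC1c1ccccc1` gives 2.4 in this assay. Compound 2 `O=C(C1CCN(c2cccnn2)CC1)N1N=CC[C@H]1c1ccccc1` gives 3.4 in this assay, and compound 3 `CC(C)(C)C(=O)N1N=CCC1c1cc(F)cc(F)c1` gives 6.3 in this assay. Among these three numbers compound 2 stands second highest: compound 1 lies below it by more than the usual scatter of repeated measurements, while compound 3 lies far above it, again beyond the scatter, so the three results are spread out rather than bunched.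

Compound 4 `CC(=O)N1CCC(C(=O)N2N=CC[C@H]2c2ccccc2)CC1` has not yet been measured in this assay. It differs from compound 2 in one place: acetyl in place of pyridazin-3-yl on an amine nitrogen in a ring. A ring-bearing group leaves and a short group with no ring enters, and in this assay such a change is expected to show up as a fall. The step from compound 2 to compound 4 is estimated as a clear drop of a number 1.40 log units lower from compound 2 to compound 4 (beyond the scatter), well beyond the scatter. Compound 4 is therefore expected to give about 2 in this assay, most likely between 1.4 and 2.6.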

Compound 4, distribution coefficient: 2.5
For compound 4 the middle estimate is 0.50 log units below the measured one; measured number inside the range.
By their numbers in this assay, from the lowest: compounds 1 and 4 (each within the scatter of the next); then compound 2; then compound 3.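

In this assay, within the data shown here, the change on the amine nitrogen in a ring gives a number 0.90 log units lower from compound 2 to compound 4 (beyond the scatter), the first step here in which only one place differs. It shows that the group on this nitrogen affects the read-out, with acetyl, a group with no ring, giving the lower number of the pair. The data at hand offer no explanation for this fall.

This single pair cannot show whether the step follows from the pyridazin-3-yl ring leaving or from the acetyl group entering, since both happen at once; an ethyl chain or a benzoyl group on the same nitrogen would help to separate the two. From the compounds shown here alone, whether the same swap would give a similar step on the core of compound 1 or compound 3 also remains open.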